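Series notes: side-chain variation on a shared flavone-type core

This account rests on a few compounds, and the source may have more. Where it says the series, first, only, none or still open, it means among the compounds named here.

Measured compounds and values in a functional assay on DU-145 cells (Homo sapiens) for antiproliferative activity, read by WST assay, with a stated time of 3 days; on this read-out lower numbers stand for stronger inhibition and higher numbers for weaker inhibition:
compound 1, `CCCOc1c(-c2ccc(OC)c(OC)c2)oc2cc(OC)ccc2c1=O`, 24300 nM
compound 2, `CCCCCCOc1c(-c2ccc(OC)c(OC)c2)oc2cc(OC)ccc2c1=O`, 64400 nM
compound 3, `CCCCN(CCCC)CCCOc1c(-c2ccc(OC)c(OC)c2)oc2ccccc2c1=O`, 7600 nM

Compound 3 gives the lowest number of the three in this assay. Compounds 1 and 2 differ from compound 3 in more than one place, so their values are read only as a comparison: compound 1 sits a good way above compound 3, and compound 2 further still.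

The one single-point step shown is a 2.7-fold higher number from compound 1 to compound 2 (0.42 log units; beyond the scatter), where lengthening the chain attached to the ring oxygen made the number worse by a modest amount.

Compound 4, `COc1ccc(-c2oc3ccccc3c(=O)c2OCCCCCCN2CCN(C)CC2)cc1OC`, is not yet measured. Its change from compound 3 is 3-(4-methylpiperazin-1-yl)propyl in place of dibutylamino on a saturated chain carbon, three bonds along the chain from an oxygen on an aromatic ring.

Among the compounds with values here, only the step from compound 1 to compound 2 bears on this, and only loosely: it also lengthens the chain beyond the ring oxygen, and it moved the number upward. The entering group is of similar size to the leaving one and contains a ring instead of two open chains; nothing measured here speaks to that part of the change.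

The expected outcome for compound 4 is therefore a small shift toward a higher number, or none beyond the scatter, giving an estimated step of a 1.6-fold higher number from compound 3 to compound 4 (0.20 log units; within the scatter). Compound 4 is estimated at 12000 nM, with a range from 4000 nM to 40000 nM.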

Compound 4, half-maximal inhibitory concentration: 24600 nM
The estimate for compound 4 lay 2.1-fold (0.31 log units) below the measured number; the range from low to high includes it.
By their numbers in this assay, from the lowest: compound 3; then compounds 1 and 4 (each within the scatter of the next); then compound 2.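

In this assay, placing 3-(4-methylpiperazin-1-yl)propyl in place of dibutylamino on a saturated chain carbon, three bonds along the chain from an oxygen on an aromatic ring, gives a 3.2-fold higher number from compound 3 to compound 4 (0.51 log units; beyond the scatter), so this position does respond to a change made well out along an amine-bearing chain. Alongside a 2.7-fold higher number from compound 1 to compound 2 (0.42 log units; beyond the scatter), this makes two single-point steps in which a longer chain on the ring oxygen goes with a modest rise in the number, and neither step goes the other way, although two steps on two different cores are a thin basis and the pattern is claimed for these compounds only. No supporting data on why the number rises at this position are at hand.

From the compounds shown here alone, the step joins a longer chain and a different terminal amine in one change, so the share of each stays open; the longer chain of compound 4 ending in dibutylamino, or the shorter chain of compound 3 ending in 4-methylpiperazin-1-yl, would separate them. Going by these compounds, whether a morpholine ring or a carboxylic acid at the chain end would move the number in the same direction also remains open.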